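This account rests on a few compounds, and the source may have more. Where it says the series, first, only, none or still open, it means among the compounds named here.

Working notes on the series. In an assay on isolated protein for binding affinity to leukotriene B4 receptor 1 (Homo sapiens), tested at 1 uM (a higher number here means more inhibition at the concentration tested (going by the name of the read-out), a lower number less inhibition), compound 1 `C=CCc1cc(C(C)=O)c(O)cc1OCCCCC` gives 23%. In this assay compound 2 `C=CCCCCOc1cc(O)c(C(C)=O)cc1CC=C` gives 27%. In this assay, within the data shown here, compound 3 `C=CCc1cc(C(C)=O)c(O)cc1OCCCCO` gives 9%, the lowest of the three numbers so far: the nearest is compound 1 and the furthest compound 2, both separated from compound 3 by more than the scatter.

Compound 4 `C=CCc1cc(C(C)=O)c(O)cc1OCCCCCC(=O)OC` is not yet measured. Relative to compound 3 the change is (methoxycarbonyl)methyl in place of hydroxy on a saturated chain carbon, four bonds along the chain from an oxygen on an aromatic ring.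

Among the measured compounds shown here, three measured steps touch the same chain carbon. From compound 1 to compound 2 the number moved by a number 4 percentage points higher from compound 1 to compound 2 (within the scatter). From compound 1 to compound 3 it moved by a number 14 percentage points lower from compound 1 to compound 3 (beyond the scatter), and from compound 2 to compound 3 by a number 18 percentage points lower from compound 2 to compound 3 (beyond the scatter). Replacing the hydroxy at this position by a group without a hydrogen-bond donor has, in both directions seen, gone with a modest rise; whether a (methoxycarbonyl)methyl group behaves like methyl or vinyl here is not known from the three compounds.

Compound 4 is therefore expected to recover part of the drop, with a step of a number 11 percentage points higher from compound 3 to compound 4 (beyond the scatter) expected in this assay. The estimate for compound 4 is 20%, with a range from 5% to 38%.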

Compound 4, a percentage reported as inhibition, at one concentration (the size of the read-out at that concentration, not a potency): 65%
The estimate for compound 4 lay 45 percentage points below the measured number; measured number outside the range, above it.
By their numbers in this assay, from the lowest: compound 3; then compounds 1 and 2 (each within the scatter of the next); then compound 4.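

At this chain end in this assay a step can be large: (methoxycarbonyl)methyl in place of hydroxy gives a number 56 percentage points higher from compound 3 to compound 4 (beyond the scatter) and carries the series well past the level of the ends seen before. Removing the hydroxy alone does not account for this level, since the methyl and vinyl ends, which also lack it, differ from each other only by a number 4 percentage points higher from compound 1 to compound 2 (within the scatter) and both stand clearly under the ester end. The ester end gives a number 38 percentage points higher from compound 2 to compound 4 (beyond the scatter) and a number 42 percentage points higher from compound 1 to compound 4 (beyond the scatter) so the gain goes with the methoxycarbonyl-bearing chain, not merely with a chain end free of a hydrogen-bond donor.

From the compounds shown here alone, whether the gain belongs to the methyl ester itself or to the longer chain that carries it stays open, and a carboxylic acid or a primary amide at the same chain end, or a methyl ester on a shorter chain, would separate the two. No measurement on hand bears on why this chain end stands apart.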